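Hydroxyalkyl amide variants: from compound 3 to compound 4

A few compounds are considered here, and "the series" means these few. Any claim that something is new, unique, unknown or untested is made for them only; others in the source may bear on it.

In a functional assay on PC-3 cells (Homo sapiens) for antiproliferative activity, read by MTT assay, with a stated time of 24 h (on this read-out higher numbers stand for weaker inhibition and lower numbers for stronger inhibition), compound 1 (`CCn1c(C(=O)N[C@H](C)CO)ccc1C(CC)(CC)c1ccc(OCS(=O)(=O)c2ccccc2)c(C)c1`) gives 7790 nM, compound 2 (`CCn1c(C(=O)NC2(CO)CC2)ccc1C(CC)(CC)c1ccc(OCS(=O)(=O)c2ccccc2)c(C)c1`) gives 3560 nM and compound 3 (`CCn1c(C(=O)NCCCO)ccc1C(CC)(CC)c1ccc(OCS(=O)(=O)c2ccccc2)c(C)c1`) gives 11300 nM. Compound 3 is level with the other open-chain member, with a 1.5-fold higher number from compound 1 to compound 3 (0.16 log units; within the scatter). The cyclopropyl member stands apart, with a 3.2-fold higher number from compound 2 to compound 3 (0.50 log units; beyond the scatter).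

Compound 4 (`CCn1c(C(=O)N[C@@H](CO)CCCO)ccc1C(CC)(CC)c1ccc(OCS(=O)(=O)c2ccccc2)c(C)c1`) differs from compound 3 by a group of 7 heavy atoms (5 carbon, 2 oxygen; no ring) in place of a group of 4 heavy atoms (3 carbon, 1 oxygen; no ring), on an amide-type nitrogen. The change sits on the amide-type nitrogen, and the entering group has no ring and carries 1 defined stereocentre. All measured steps fall at this same nitrogen, but none involves a group of this size, so they guide the estimate only loosely. The ring-bearing compound 2 accounts for both steps beyond the scatter, a 2.2-fold lower number from compound 1 to compound 2 (0.34 log units; beyond the scatter) and a 3.2-fold higher number from compound 2 to compound 3 (0.50 log units; beyond the scatter), and both are modest. Neither compound 3 nor compound 4 has a ring in this group, and the open-chain comparison gave a 1.5-fold higher number from compound 1 to compound 3 (0.16 log units; within the scatter). An estimated 1.3-fold lower number from compound 3 to compound 4 (0.10 log units; within the scatter) therefore means no expected change beyond the scatter. Compound 4 is expected at 9000 nM, with an estimated range of 4000 nM to 22000 nM.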

Compound 4, half-maximal inhibitory concentration: 13400 nM
Compound 4: the middle estimate sits 1.5-fold (0.17 log units) below what was measured, and the stated range covers the measured number.
By their numbers in this assay, from the lowest: compound 2; then compounds 1, 3 and 4 (each within the scatter of the next).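

In this assay, the larger open-chain group, with 2 hydrogen-bond donors, leaves the number within the scatter of the 3-hydroxypropyl amide, at a 1.2-fold higher number from compound 3 to compound 4 (0.07 log units; within the scatter), and 2-hydroxyethyl in place of hydrogen on the chain carbon also stays within the scatter, at a 1.7-fold higher number from compound 1 to compound 4 (0.24 log units; within the scatter). The open-chain groups on this amide-type nitrogen thus form one level despite their differing size, while the 1-(hydroxymethyl)cyclopropyl member stays apart, with a 3.8-fold higher number from compound 2 to compound 4 (0.58 log units; beyond the scatter). No available evidence bears on what lies behind either the level or the gap.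

As far as these compounds go, it remains open whether an amine or a carboxylic acid in place of a hydroxyl would leave that level. A 1-(hydroxymethyl)cyclobutyl group would test whether the lower number of compound 2 extends beyond the three-membered ring.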